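Replacing the chain end of compound 2 with hydroxycarbamoyl

The source may hold more compounds than are shown below. What is called first, only, known or untested is meant among the compounds shown, and "the series" means these compounds.

In an ADME assay on microsomes from liver (Rattus norvegicus) for metabolic stability, read by HPLC, using NADPH, with a stated time of 1 h, tested at 10 ug/mL (on this read-out higher numbers stand for a more stable compound and lower numbers for a less stable compound), compound 2 (`CNC(=O)CCCCCCCn1nc(-c2ccc3oc(N)nc3c2)c2c(N)ncnc21`) gives 63.9% and stands within the usual scatter of compound 1 (`Nc1ncnc2c1c(-c1cnc3[nH]ccc3c1)nn2CCCCCCCCC(=O)NO`) at 55.3% in this set of two numbers. Compound 3 (`Nc1nc2cc(-c3nn(CCCCCCC(=O)NO)c4ncnc(N)c34)ccc2o1`) awaits measurement. Its structure departs from that of compound 2 (hydroxycarbamoyl in place of (methylcarbamoyl)methyl on a saturated chain carbon, six bonds along the chain from an aromatic nitrogen) on a saturated chain carbon, six bonds along the chain from an aromatic nitrogen, where hydroxycarbamoyl stands in place of (methylcarbamoyl)methyl. For the measured compounds named here, no measured pair isolates this change. Going by the values given here, the only guide is compound 1 with its 55.3% as the one measured compound that also carries hydroxycarbamoyl, though it differs from compound 3 elsewhere too. A small downward move that stays inside the scatter is therefore expected, with an estimated a number 8.9 percentage points lower from compound 2 to compound 3 (within the scatter) as its size. For compound 3 the expected value is 55% with an estimated range from 36% to 72% in this assay.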

Compound 3, percent of the compound remaining: "stable" (no number reported)
Compound 3: no number reported, so the estimate cannot be set against anything.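

For the compounds shown here, compound 3 is reported in this assay as a word rather than a number, so no step from compound 2 to compound 3 can be read. No evidence bears on this result. The compounds shown leave open how far hydroxycarbamoyl in place of (methylcarbamoyl)methyl shifts the percent of compound remaining.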